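The source may report more compounds than this note shows. Statements on the series, on what has been measured and on what is new or still open speak of the compounds shown alone.

In a functional assay on BT-474 cells (Homo sapiens) for inhibition, read by MTT assay, with a stated time of 5 days (a lower number here means a stronger inhibitor, a higher number a weaker inhibitor), compound 1 `Cc1cc(Nc2nc(NCc3ccc(Cl)cc3)nc3[nH]ncc23)n[nH]1` gives 11700 nM, compound 2 `Cc1cc(Nc2nc(NCc3ccc(Cl)cc3)nc3c2cnn3C2CCOCC2)n[nH]1` gives 18300 nM and compound 3 `Cc1cc(Nc2nc(NCc3ccc(Cl)cc3)nc3c2cnn3CC(C)(C)O)n[nH]1` gives 16200 nM. Compound 3 therefore stands level with the other two, its value lying within the scatter of both. Compound 4 `Cc1cc(Nc2nc(NCc3ccc(Cl)cc3)nc3c2cnn3C(C)C)n[nH]1` has isopropyl in place of 2-hydroxy-2-methylpropyl on an aromatic nitrogen. Three measured steps on that nitrogen bear on this change: a 1.4-fold higher number from compound 1 to compound 3 (0.14 log units; within the scatter), a 1.6-fold higher number from compound 1 to compound 2 (0.19 log units; within the scatter) and a 1.1-fold lower number from compound 2 to compound 3 (0.05 log units; within the scatter). All three lie within the scatter, so no step beyond the scatter is expected in this assay. The estimated step is a 1.1-fold lower number from compound 3 to compound 4 (0.03 log units; within the scatter). For compound 4 the estimate is 15000 nM, with an expected range of 8000 nM to 28000 nM.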

Compound 4, half-maximal inhibitory concentration: 13000 nM
Estimate against measurement, compound 4: 1.2-fold (0.06 log units) above, within the range that was stated.
By their numbers in this assay, from the lowest: compounds 1, 4, 3 and 2 (each within the scatter of the next).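

In this assay, isopropyl carries no hydrogen-bond donor or acceptor, yet exchanging 2-hydroxy-2-methylpropyl for it leaves the number within the scatter (a 1.2-fold lower number from compound 3 to compound 4 (0.10 log units; within the scatter)). Isopropyl is also level with oxan-4-yl (a 1.4-fold lower number from compound 2 to compound 4 (0.15 log units; within the scatter)) and with hydrogen (a 1.1-fold higher number from compound 1 to compound 4 (0.05 log units; within the scatter)), so all four groups shown on this aromatic nitrogen give values within the scatter of one another. No available evidence accounts for this flat result.

As far as these compounds go, whether an amine, a carboxylic acid or a longer chain on this nitrogen would give a step beyond the scatter remains open.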